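A few compounds are considered here, and "the series" means these few. Any claim that something is new, unique, unknown or untested is made for them only; others in the source may bear on it.

Among the measured compounds shown here, in an ADME assay on A549 cells (Homo sapiens) for cytotoxicity, read by CellTiter-Glo (on this read-out lower numbers stand for higher toxicity in this test and higher numbers for lower toxicity in this test), compound 3 `Cc1c(Cc2ccccc2)c(=O)oc2cc(OCC(O)CNCCCO)ccc12` gives 53400 nM, the only true number in this small series. Compound 1 `Cc1c(Cc2ccccc2)c(=O)oc2cc(OCC(O)CNCC3CC3)ccc12` reads > 100000 nM, which is a limit of the assay and not a number. Compound 2 `Cc1c(Cc2ccccc2)c(=O)oc2cc(OCC(O)CNc3ccc(Br)cc3)ccc12` reads > 100000 nM, also a limit. Compound 4 `Cc1c(Cc2ccccc2)c(=O)oc2cc(OCC(O)CNCc3cccs3)ccc12` has thiophen-2-yl in place of 2-hydroxyethyl on a saturated chain carbon bound to an amine nitrogen. The closest guides are two measured steps that end on the 3-hydroxypropyl group: an at least 1.8-fold lower number from compound 1 to compound 3 (0.27 log units; that floor lies within the scatter) and an at least 1.8-fold lower number from compound 2 to compound 3 (0.27 log units; that floor lies within the scatter). Compound 4 gives up that group, so no step beyond the scatter is expected, and the estimated change is a 1.3-fold higher number from compound 3 to compound 4 (0.12 log units; within the scatter). The expected value for compound 4 is 70000 nM, within an estimated range of 30000 nM to 100000 nM.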

Compound 4, half-maximal cytotoxic concentration: 87300 nM
The estimate for compound 4 lay 1.2-fold (0.10 log units) below the measured number, within the range that was stated.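

In this assay, thiophen-2-yl can take the place of 2-hydroxyethyl on a saturated chain carbon bound to an amine nitrogen with no change beyond the scatter (a 1.6-fold higher number from compound 3 to compound 4 (0.21 log units; within the scatter)). The hydroxyl group of compound 3 is therefore not needed for a number in this range, and the floors against the other two compounds also stay within the scatter (an at least 1.1-fold lower number from compound 2 to compound 4 (0.05 log units; that floor lies within the scatter)) and (an at least 1.1-fold lower number from compound 1 to compound 4 (0.05 log units; that floor lies within the scatter)). Compound 1 and compound 2 each rest on a limit, not a number: the limit of > 100000 nM in this assay, at which 2 of the 4 values shown sit.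

The step between compound 1 and compound 2 cannot be read. Going by these compounds, how a carboxylic acid, an amine or a longer chain would read at this place stays open.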